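A few compounds are considered here, and "the series" means these few. Any claim that something is new, unique, unknown or untested is made for them only; others in the source may bear on it.

Measured compounds:
compound 1 `COc1ccccc1N1CCN(CCC(Oc2ccc(NC(=O)c3ccccc3OCCCC(=O)O)cc2)c2ccc(C)cc2)CC1` in an assay on isolated protein for inhibition of steroid 5-alpha-reductase (Rattus norvegicus) (on this read-out higher numbers stand for weaker inhibition and lower numbers for stronger inhibition), gives 440 nM
compound 2 `CCc1ccc(C(CCN2CCN(c3ccccc3OC)CC2)Oc2ccc(NC(=O)c3ccccc3OCCCC(=O)O)cc2)cc1` gives 130 nM
compound 3 `COc1ccccc1N1CCN(CCC(Oc2ccc(C(=O)Nc3ccccc3OCCCC(=O)O)cc2)c2ccccc2)CC1` gives 1000 nM

Compound 3 stands at the highest number of the three, that is the weakest inhibition shown; the nearest is compound 1 and the furthest is compound 2, both lower than compound 3 by more than the scatter. The shared core carries the same acid chain and amide, the three differing in how the amide is joined and in the substituent on the phenyl next to the ether carbon.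

Compound 4 `CCc1ccc(C(CCN2CCN(c3ccccc3OC)CC2)Oc2ccc(C(=O)Nc3ccccc3OCCCC(=O)O)cc2)cc1` is not yet measured. It differs from compound 3 by ethyl in place of hydrogen on an aromatic carbon. For the measured compounds named here, the one measured step that bears on this place is a 3.4-fold lower number from compound 1 to compound 2 (0.53 log units; beyond the scatter), which extends a methyl to an ethyl on the same ring of the core of compound 1 and lowers the number. Going by the values given here, no step from hydrogen to methyl at that position has been measured, so the full change from hydrogen to ethyl is only partly covered. Taking the measured step as a guide, the move from compound 3 to compound 4 is expected to lower the number by about a 4.0-fold lower number from compound 3 to compound 4 (0.60 log units; beyond the scatter). Compound 4 is therefore estimated at 250 nM, with a range from 100 nM to 600 nM in this assay.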

Compound 4, half-maximal inhibitory concentration: 70 nM
For compound 4 the middle estimate is 3.6-fold (0.55 log units) above the measured one, and the stated range ends above it.
By their numbers in this assay, from the lowest: compounds 4 and 2 (each within the scatter of the next); then compound 1; then compound 3.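

In this assay, ethyl in place of hydrogen on the aromatic carbon para to a large group gives a 14-fold lower number from compound 3 to compound 4 (1.15 log units; beyond the scatter), a large step. For the compounds shown here, this is the first reading of the whole change from phenyl to 4-ethylphenyl, as the earlier compounds held only the modest 3.4-fold lower number from compound 1 to compound 2 (0.53 log units; beyond the scatter), which starts from methyl on a core with the amide joined the other way round. The two ethyl compounds, compound 2 and compound 4, lie within the scatter of each other, so on the values shown the ethyl group holds up on both cores.

No measurement at hand gives a reason for the size of the step from hydrogen to ethyl. As far as these compounds go, how much of that step a single methyl on the core of compound 3 would carry stays open, as does how a longer chain such as propyl, or an amine, would read in the same place.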